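This account rests on a few compounds, and the source may have more. Where it says the series, first, only, none or still open, it means among the compounds named here.

In a functional assay on KB cells (Homo sapiens), read by crystal violet staining (on this read-out higher numbers stand for weaker inhibition and lower numbers for stronger inhibition), compound 1 `CS(=O)(=O)N1CC(CCl)c2cc(Br)c(O)cc21` gives 3.8 ug/mL, compound 2 `CS(=O)(=O)N1CC(CCl)c2cc([N+](=O)[O-])c(O)cc21` gives 8.85 ug/mL and compound 3 `COC(=O)c1cc2c(cc1OCc1ccccc1)N(S(C)(=O)=O)CC2CCl` gives 7.14 ug/mL. Compound 3 therefore stands second highest of the three numbers; its nearest neighbour is compound 2, and its furthest is compound 1, and both gaps lie within the scatter, so the three compounds cannot be ordered against one another on this read-out. For the measured compounds named here, the only step between measured compounds that differ in one place is a 2.3-fold higher number from compound 1 to compound 2 (0.37 log units; beyond the scatter), a modest change for nitro in place of bromo.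

Compound 4 `COC(=O)c1cc2c(cc1O)N(S(C)(=O)=O)CC2CCl` differs from compound 3 by hydrogen in place of benzyl on an oxygen on an aromatic ring. Going by the values given here, no measured step follows a benzyl leaving an oxygen on an aromatic ring, so the step from compound 1 to compound 2 bears on it only indirectly, by showing how small a single change at the ring has been; in compounds 1 and 2 the oxygen on the ring already carries hydrogen. On that basis, for compound 4 in this assay a step of a 1.3-fold lower number from compound 3 to compound 4 (0.11 log units; within the scatter) is expected, not beyond the scatter. The estimate for compound 4 is 5.5 ug/mL, with a range from 2.2 ug/mL to 14 ug/mL.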

Compound 4, half-maximal inhibitory concentration: 8.38 ug/mL
Compound 4: the middle estimate sits 1.5-fold (0.18 log units) below what was measured; the measured number falls inside the stated range.
By their numbers in this assay, from the lowest: compounds 1, 3, 4 and 2 (each within the scatter of the next, the first and the last beyond it).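

Taking benzyl off the oxygen on the aromatic ring, benzyloxy to hydroxy, gives a 1.2-fold higher number from compound 3 to compound 4 (0.07 log units; within the scatter) in this assay, so on this read-out the free hydroxy and the benzyl ether cannot be told apart when methoxycarbonyl is on the aromatic carbon. At that aromatic carbon, methoxycarbonyl in place of nitro gives a 1.1-fold lower number from compound 2 to compound 4 (0.02 log units; within the scatter), whereas methoxycarbonyl in place of bromo gives a 2.2-fold higher number from compound 1 to compound 4 (0.34 log units; beyond the scatter), so nitro and methoxycarbonyl stand level and each sits a modest step from bromo. Nothing shown here accounts for these numbers.

From the compounds shown here alone, the benzyl step rests on one pair, so whether it holds with bromo or nitro on the aromatic carbon remains open. Also open, going by these compounds, is how a methyl ether on that oxygen, or an amine or a carboxylic acid on the aromatic carbon, would compare.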